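Methylamine in place of amine on a chromene pair

The source may hold more compounds than are shown below. What is called first, only, known or untested is meant among the compounds shown, and "the series" means these compounds.

Measured compounds:
compound 1, `C=C(c1ccc(OC)cc1NC(=O)CN)c1ccc(OC)c2c1C=CC(C)(C)O2`, 520 nM
compound 2, `C=C(c1ccc2c(c1)C=CC(C)(C)O2)c1ccc(OC)cc1NC(=O)CN`, 220 nM
compound 3, `C=C(c1ccc(OC)cc1NC(=O)CNC)c1ccc(OC)c2c1C=CC(C)(C)O2`, 980 nM

All three were tested in a functional assay on HCT-8 cells (Homo sapiens) for antiproliferative activity, read by MTT assay, with a stated time of 48 h; a lower number here means a stronger inhibitor, a higher number a weaker inhibitor. Compound 2 gives the lowest of the three numbers in this assay, and its gap to compound 1 is beyond the scatter. The cores of compound 1 and compound 2 differ, but that difference is not broken down here.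

Going by the values given here, from compound 1 to compound 3 the only change is methyl in place of hydrogen on an amine nitrogen, and the step is a 1.9-fold higher number from compound 1 to compound 3 (0.28 log units; within the scatter). The unmeasured compound 4, `C=C(c1ccc2c(c1)C=CC(C)(C)O2)c1ccc(OC)cc1NC(=O)CNC`, is made from compound 2 by the same change, (methyl in place of hydrogen on an amine nitrogen).

Because compound 3 stands at 980 nM next to compound 1, the expectation is that the step from compound 2 to compound 4 in this assay will be of similar size, a 1.8-fold higher number from compound 2 to compound 4 (0.26 log units; within the scatter), and that it stays near the scatter. Compound 4 is therefore estimated at 400 nM in this assay, with a range expected between 180 nM and 900 nM.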

Compound 4, half-maximal inhibitory concentration: 590 nM
Compound 4: middle estimate off by 1.5-fold (0.17 log units), on the low side; the measured number falls inside the stated range.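

In this assay, methyl in place of hydrogen on an amine nitrogen gives a 2.7-fold higher number from compound 2 to compound 4 (0.43 log units; beyond the scatter). Going by these compounds alone, although only this step clears the scatter on its own, the two steps cannot be told apart, so the change carries from one core to the other without a measurable difference: the same change on two cores in this assay, a 1.9-fold higher number (0.28 log units; within the scatter) from compound 1 to compound 3 and a 2.7-fold higher number (0.43 log units; beyond the scatter) from compound 2 to compound 4, 1.4-fold (0.15 log units) apart, within the scatter of two such steps. This shows only that amino to methylamino can be read as a step of similar size on these two cores; it does not show that the step would hold on a further core, and it gives no explanation for its size.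

The compounds shown leave open how the same amine nitrogen behaves with a second methyl, as in a dimethylamino group, or with a longer chain such as ethyl or propyl. They also leave open whether a cyclic amine such as pyrrolidine, or a hydroxyl group in place of the amine, would fit the same picture on either core.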